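The source may hold more compounds than are shown below. What is called first, only, known or untested is meant among the compounds shown, and "the series" means these compounds.

Of the compounds shown here, three of a shared core have been measured in a functional assay on KBVIN cells (Homo sapiens) for antiproliferative activity, read by sulforhodamine B assay, with a stated time of 3 days; on this read-out lower numbers stand for an effect already at smaller amounts and higher numbers for an effect only at larger amounts of compound. Compound 1 `CCC1=C(O)c2c(oc(-c3ccc(CC)cc3)cc2=O)C(CC)(CC)C1=O` gives 0.07 uM, compound 2 `CCC1=C(O)c2c(oc(-c3ccc(O)cc3)cc2=O)C(CC)(CC)C1=O` gives 20.6 uM, and compound 3 `CCC1=C(O)c2c(oc(-c3ccc(OC)cc3C)cc2=O)C(CC)(CC)C1=O` gives 2.62 uM. Compound 3 therefore holds the second highest of the three numbers: its nearest neighbour is compound 2, reached by a 7.9-fold lower number from compound 2 to compound 3 (0.90 log units; beyond the scatter), while compound 1 lies furthest, with a 37-fold higher number from compound 1 to compound 3 (1.57 log units; beyond the scatter).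

Compound 4 `CCC1=C(O)c2c(oc(-c3cc(C)ccc3C)cc2=O)C(CC)(CC)C1=O` has not yet been measured. It differs from compound 3 in one place: 2,5-dimethylphenyl in place of 4-methoxy-2-methylphenyl on an aromatic carbon.

Two measured steps speak to this change. The swap from compound 1 to compound 2 replaced an alkyl group with a hydroxy group and produced a 290-fold higher number from compound 1 to compound 2 (2.47 log units; beyond the scatter); the swap from compound 1 to compound 3 brought in the methoxy-bearing ring and produced a 37-fold higher number from compound 1 to compound 3 (1.57 log units; beyond the scatter). In both cases the ring without an oxygen gave the lower number. Compound 4 carries only carbon on its phenyl ring, as compound 1 does, although the methyl groups sit at different positions from the ethyl of compound 1, so the gain is expected to be smaller than a full return to compound 1.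

The expected step from compound 3 to compound 4 in this assay is thus a 5.2-fold lower number from compound 3 to compound 4 (0.72 log units; beyond the scatter). Compound 4 is estimated at 0.5 uM, with a range from 0.1 uM to 3 uM.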

Compound 4, concentration for half-maximal effect: 3.41 uM
Compound 4: the middle estimate sits 6.8-fold (0.83 log units) below what was measured; the whole stated range lies below it.
By their numbers in this assay, from the lowest: compound 1; then compounds 3 and 4 (each within the scatter of the next); then compound 2.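

In this assay, putting 2,5-dimethylphenyl in place of 4-methoxy-2-methylphenyl on this aromatic carbon, next to the ring oxygen, gives a 1.3-fold higher number from compound 3 to compound 4 (0.11 log units; within the scatter) and so leaves the two rings indistinguishable. A ring carrying only carbon groups is therefore not enough on its own to reach the low number of the 4-ethylphenyl ring: 2,5-dimethylphenyl in place of 4-ethylphenyl gives a 49-fold higher number from compound 1 to compound 4 (1.69 log units; beyond the scatter) even though neither ring holds an oxygen, while the same group in place of 4-hydroxyphenyl gives a 6.0-fold lower number from compound 2 to compound 4 (0.78 log units; beyond the scatter) and keeps a clear distance from the hydroxy compound as well. Nothing at hand explains why these rings fall where they do.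

The compounds shown do not separate the effect of the ring methyl groups from that of losing the ethyl group, as each ring differs from 4-ethylphenyl in more than one feature. They also leave open how a longer chain such as propyl in place of the ethyl of compound 1, or an amine in place of the hydroxy of compound 2, would read on this position.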